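Pyrazole in place of pyridine on a thienyl core

The source may report more compounds than this note shows. Statements on the series, on what has been measured and on what is new or still open speak of the compounds shown alone.

Three compounds share the same bicyclic core and differ only in the aromatic group attached to it. In an assay for inhibition of Rho-associated protein kinase 1 (Homo sapiens), read by TR-FRET, with stated times of 5 min and 2 h (on this read-out higher numbers stand for weaker inhibition and lower numbers for stronger inhibition), compound 1 `Cc1n[nH]c(C)c1-c1cc2c(s1)C(=O)NC(C)(C)N2C` gives 2100 nM and compound 2 `CCc1n[nH]cc1-c1cc2c(s1)C(=O)NC(C)(C)N2C` gives 350 nM. Compound 3 `CN1c2cc(-c3ccncc3)sc2C(=O)NC1(C)C` gives 140 nM in this assay, the lowest of the three numbers: its separation from compound 2 and its separation from compound 1 both lie beyond the usual scatter, so compound 3 is the most potent of the three.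

Compound 4 `Cc1n[nH]cc1-c1cc2c(s1)C(=O)NC(C)(C)N2C` has not yet been measured. It differs from compound 3 by 3-methyl-1H-pyrazol-4-yl in place of pyridin-4-yl on an aromatic carbon. Since compound 2 with its ethyl-bearing pyrazole gives 350 nM and compound 1 with two methyl groups on the pyrazole gives 2100 nM, the pyrazole-bearing compounds sit above compound 3, and compound 4 is expected to follow them. The step is estimated as a 2.1-fold higher number from compound 3 to compound 4 (0.33 log units; beyond the scatter), a modest loss of potency beyond the scatter. Compound 4 is therefore expected to give about 300 nM in this assay, with a plausible range from 100 nM to 900 nM.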

Compound 4, half-maximal inhibitory concentration: 54 nM
Estimate against measurement, compound 4: 5.6-fold (0.74 log units) above; measured number outside the range, below it.
By their numbers in this assay, from the lowest: compound 4; then compound 3; then compound 2; then compound 1.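

In this assay the change to 3-methyl-1H-pyrazol-4-yl on this aromatic carbon next to the ring sulfur gives a 2.6-fold lower number from compound 3 to compound 4 (0.41 log units; beyond the scatter) and so shows that a pyrazole here can outdo pyridin-4-yl, which compounds 1 and 2 gave no sign of. The pyrazole also responds strongly to small changes: methyl in place of ethyl gives a 6.5-fold lower number from compound 2 to compound 4 (0.81 log units; beyond the scatter) as one step, and hydrogen in place of the second ring methyl gives a 39-fold lower number from compound 1 to compound 4 (1.59 log units; beyond the scatter) as a large one. Compound 4 is thus the most potent of the four, and among the pyrazoles the substituents, not the ring alone, set the number.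

On these data alone, whether a pyrazole with no methyl at all, or one carrying an amine or a methoxy group in that place, would go lower remains open. The data offer no evidence on why these steps run as they do.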